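The compounds below may be only part of what the source reports. "The series", "measured", "known", "first", "only" and "open" are said of these compounds alone.

Measured in a functional assay on MCF7 cells (Homo sapiens) for inhibition, read by MTT assay, with a stated time of 72 h; a lower number here means a stronger inhibitor, a higher number a weaker inhibitor:

compound 1 `Cc1ccc(-c2nnc(SCCCN3CCN(c4nc5ccccc5o4)CC3)o2)cc1` gives 60400 nM
compound 2 `Clc1ccc(-c2nnc(SCCCN3CCN(c4nc5ccccc5o4)CC3)o2)cc1` gives 99700 nM
compound 3 `Cc1ccc(-c2nnc(SCCCN3CCN(c4nc5ccccc5s4)CC3)o2)cc1` gives 107000 nM

All three numbers sit close together at the weak end, and none of the steps between them is outside the scatter. The change from compound 1 to compound 2 is chloro in place of methyl on an aromatic carbon; it gives a 1.7-fold higher number from compound 1 to compound 2 (0.22 log units; within the scatter). The change from compound 1 to compound 3 is 1,3-benzothiazol-2-yl in place of 1,3-benzoxazol-2-yl on an amine nitrogen in a ring; it gives a 1.8-fold higher number from compound 1 to compound 3 (0.25 log units; within the scatter). Compound 2 and compound 3 differ by both changes at once and their two values lie within the scatter of each other, so no order can be read among them.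

Compound 4 `Clc1ccc(-c2nnc(SCCCN3CCN(c4nc5ccccc5s4)CC3)o2)cc1` is not yet measured in this assay. It differs from compound 3 by chloro in place of methyl on an aromatic carbon. This is the same change as that from compound 1 to compound 2: the place lines read alike word for word, and only the core differs, in the way just described for compound 3 against compound 1.

The step from compound 3 to compound 4 in this assay is expected to be about a 1.6-fold higher number from compound 3 to compound 4 (0.20 log units; within the scatter), resting on the earlier step of a 1.7-fold higher number from compound 1 to compound 2 (0.22 log units; within the scatter) applied to the value of compound 3, 107000 nM. On that basis compound 4 is estimated at 170000 nM, with a range from 80000 nM to 350000 nM; with so weak a starting point, a limit rather than a number is a real possibility.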

Compound 4, half-maximal inhibitory concentration: 116000 nM
Beside the measured number, compound 4's estimate is 1.5-fold (0.17 log units) above it, within the range that was stated.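

In this assay, 4-chlorophenyl in place of 4-methylphenyl gives a 1.1-fold higher number from compound 3 to compound 4 (0.04 log units; within the scatter), and this reading does not differ from the earlier one on the other core: the same change on two cores in this assay, a 1.7-fold higher number (0.22 log units; within the scatter) from compound 1 to compound 2 and a 1.1-fold higher number (0.04 log units; within the scatter) from compound 3 to compound 4, 1.5-fold (0.18 log units) apart, within the scatter of two such steps. Read on the chloro side, 1,3-benzothiazol-2-yl in place of 1,3-benzoxazol-2-yl gives a 1.2-fold higher number from compound 2 to compound 4 (0.07 log units; within the scatter), and this too agrees with its earlier reading: the same change on two cores in this assay, a 1.8-fold higher number (0.25 log units; within the scatter) from compound 1 to compound 3 and a 1.2-fold higher number (0.07 log units; within the scatter) from compound 2 to compound 4, 1.5-fold (0.18 log units) apart, within the scatter of two such steps. Going by these compounds alone, every step lies within the scatter, so the four compounds show only that neither change shifts the number measurably on either core; they do not show that a change of real size would carry from one core to another, and agreement between steps this small is a weak test of transfer.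

Still open, on these data alone, is whether any other group at these places moves the number beyond the scatter at all, for example a carboxylic acid or an amine in place of chloro on the aromatic carbon, or a longer chain on the sulfur. Within the data shown here, the four compounds cover only two changes, so they say nothing about how the series behaves away from these two pairs of groups.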